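This account rests on a few compounds, and the source may have more. Where it says the series, first, only, none or still open, it means among the compounds named here.

Compound 1, `Cc1ccccc1COc1cc(O)c2c(=O)c(O)c(-c3ccccc3)oc2c1`, is one of three compounds of a shared core that carry a benzyl ether on the ring bearing the hydroxyl groups; they differ only in what sits on the pendant phenyl. In an ADME assay on Huh-5-2 cells (Homo sapiens) for cytotoxicity, read by WST assay, with a stated time of 3 days (a higher number here means that more compound is tolerated, a lower number that less compound is tolerated), compound 1 gives 17000 nM. Among the numbers shown it stands lowest. Its nearest neighbour is compound 3, `Cc1cccc(COc2cc(O)c3c(=O)c(O)c(-c4ccccc4)oc3c2)c1`, which in this assay gives 35000 nM, a step of a 2.1-fold higher number from compound 1 to compound 3 (0.31 log units; beyond the scatter). Compound 2, `COc1ccccc1COc1cc(O)c2c(=O)c(O)c(-c3ccccc3)oc2c1`, reaches only a limit of this assay, > 100000 nM, so for it no number is known; the step from compound 1 to compound 2 therefore reads as an at least 5.8-fold higher number from compound 1 to compound 2 (0.76 log units; beyond the scatter), and (the limit of > 100000 nM in this assay, at which 1 of the 3 values shown sits). Compound 4, `O=c1c(O)c(-c2ccccc2)oc2cc(OCc3ccc([N+](=O)[O-])cc3)cc(O)c12`, differs from compound 1 in one place: 4-nitrophenyl in place of 2-methylphenyl on a saturated chain carbon bound to an oxygen on an aromatic ring. On these data alone, both measured steps that change the pendant phenyl of compound 1 raised the number, and the nitro substituent is untested here, so the expected step in this assay is a 1.8-fold higher number from compound 1 to compound 4 (0.25 log units; within the scatter), a modest rise. Compound 4 is estimated at 30000 nM, with a range from 10000 nM to 100000 nM.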

Compound 4, half-maximal cytotoxic concentration: 93000 nM
The estimate for compound 4 lay 3.1-fold (0.49 log units) below the measured number; measured number inside the range.
By their numbers in this assay, from the lowest: compound 1; then compound 3; then compound 4. At a limit, above all of these: compound 2.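

In this assay, placing 4-nitrophenyl instead of 2-methylphenyl on the saturated chain carbon gives a 5.5-fold higher number from compound 1 to compound 4 (0.74 log units; beyond the scatter), and placing it instead of 3-methylphenyl gives a 2.7-fold higher number from compound 3 to compound 4 (0.42 log units; beyond the scatter). The earlier compounds shown here showed only methyl and methoxy substituents on the pendant phenyl, whereas this result shows that a nitro-bearing phenyl, with its added nitrogen and oxygen atoms, also gives a higher number than either methyl-bearing compound. Placing 4-nitrophenyl instead of 2-methoxyphenyl gives an at least 1.0-fold lower number from compound 2 to compound 4 (0.03 log units; that floor lies within the scatter), and this step stays open-ended, because one side of it is only a limit: the limit of > 100000 nM in this assay, at which 1 of the 4 values shown sits.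

Compound 4 changes both the substituent and its place on the ring, so 4-methylphenyl and 3-nitrophenyl would be needed to separate these two changes. On these data alone, how an amine or a carboxylic acid on the pendant phenyl would read also remains open.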